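Moving Chlorines Around an Aryl Hydrazone

The source may hold more compounds than are shown below. What is called first, only, known or untested is meant among the compounds shown, and "the series" means these compounds.

Measured so far:
compound 1: `Cc1cccc(NN=C2CCC(C)n3c2ncc(C(=O)O)c3=O)c1C`, > 100 umol/kg
compound 2: `CC1CCC(=NNc2ccc(Cl)c(Cl)c2)c2ncc(C(=O)O)c(=O)n21`, > 100 umol/kg

In a functional assay on the whole organism with Rattus norvegicus as the target (a higher number here means that more compound is needed for the effect, a lower number that less compound is needed), compound 1 gives > 100 umol/kg, which is a limit of the assay and not a number. In this assay compound 2 gives > 100 umol/kg, again a limit rather than a measured number. Within the data shown here, the only measured step, a step that the two limits leave unreadable from compound 1 to compound 2, therefore cannot be read in size or direction. Compound 2 thus stands only at a limit, and the whole picture so far is summed up by the limit of > 100 umol/kg in this assay, at which 2 of the 2 values shown sit.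

Compound 3, `CC1CCC(=NNc2c(Cl)cccc2Cl)c2ncc(C(=O)O)c(=O)n21`, differs from compound 2 in one place: 2,6-dichlorophenyl in place of 3,4-dichlorophenyl on an amine nitrogen. Among the measured compounds shown here, no measured step gives a readable size for a change of this kind, since the one step available is itself unreadable. With both measured values sitting at the limit, compound 3 is expected to remain in the same region, and the expected step that the limit leaves unreadable from compound 2 to compound 3 is none beyond the usual scatter. Compound 3 is estimated at 150 umol/kg, within a range from 50 umol/kg to 450 umol/kg, with a real chance that only a limit is reported.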

Compound 3, dose for 50% inhibition: > 100 umol/kg
Compound 3 was reported as a limit (the forecaster's own chance of this, stated with the estimate: 70%); the middle value is on the limit's open side.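

In this assay compound 3 gives > 100 umol/kg, a limit of the assay and not a number. The steps linking compound 3 to compound 1 and compound 2 therefore cannot be read, and the picture stays as it was: the limit of > 100 umol/kg in this assay, at which 3 of the 3 values shown sit.

The compounds shown leave open how the three aryl groups on the amine nitrogen rank against one another, and whether any such group gives a measurable dose.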